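Moving a fluorine around the benzyl ring

The compounds below may be only part of what the source reports. "The series", "measured", "known", "first", "only" and "open" are said of these compounds alone.

Three members of this series have been tested in a functional assay on MNK45 cells (Homo sapiens) for inhibition, read by MTT assay, with a stated time of 48 h; on this read-out higher numbers stand for weaker inhibition and lower numbers for stronger inhibition. The parent, compound 1 `Cc1ccc(NC(=S)NC(=O)c2ccc(OCc3ccccc3)cc2)cc1-c1nc2ccccc2[nH]1`, gives 57800 nM in this assay. Compound 2 `Cc1ccc(NC(=S)NC(=O)c2ccc(OCc3ccc(C(F)(F)F)cc3)cc2)cc1-c1nc2ccccc2[nH]1` gives 10200 nM, and compound 3 `Cc1ccc(NC(=S)NC(=O)c2ccc(OCc3ccccc3F)cc2)cc1-c1nc2ccccc2[nH]1` gives 2420 nM, the lowest of the three numbers. The step of a 5.7-fold lower number from compound 1 to compound 2 (0.75 log units; beyond the scatter) is modest, while the step of a 24-fold lower number from compound 1 to compound 3 (1.38 log units; beyond the scatter) is large, and the step of a 4.2-fold lower number from compound 2 to compound 3 (0.62 log units; beyond the scatter) is again modest. Compound 3 therefore stands apart from both companions.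

Compound 4 `Cc1ccc(NC(=S)NC(=O)c2ccc(OCc3cccc(F)c3)cc2)cc1-c1nc2ccccc2[nH]1` is an isomer of compound 3, differing by 3-fluorophenyl in place of 2-fluorophenyl on a saturated chain carbon bound to an oxygen on an aromatic ring. Within the data shown here, none of the measured steps moves a fluorine between ring positions; the steps from compound 1 show only that a substituent on this ring, of either kind, lowers the number. The expectation for compound 4 is a modest step upward, a 2.1-fold higher number from compound 3 to compound 4 (0.32 log units; beyond the scatter), with wide uncertainty. Compound 4 is thus estimated at 5000 nM, within a range from 1500 nM to 20000 nM.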

Compound 4, half-maximal inhibitory concentration: 86800 nM
The estimate for compound 4 lay 17-fold (1.24 log units) below the measured number; measured number outside the range, above it.
By their numbers in this assay, from the lowest: compound 3; then compound 2; then compounds 1 and 4 (each within the scatter of the next).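

In this assay, the place of the fluorine on the benzyl ring proves decisive: going from 2-fluorophenyl to 3-fluorophenyl gives a 36-fold higher number from compound 3 to compound 4 (1.55 log units; beyond the scatter) even though the atoms are the same. The 3-fluorophenyl group also gives a 1.5-fold higher number from compound 1 to compound 4 (0.18 log units; within the scatter) and an 8.5-fold higher number from compound 2 to compound 4 (0.93 log units; beyond the scatter) so the earlier impression that any substituent on this ring lowers the number holds for compound 2 and compound 3 but not for compound 4. Nothing available here bears on why the two isomers differ.

The compounds shown leave open whether the low number of compound 3 belongs to fluorine itself or would survive with chloro or methoxy on the ring in its place. They also leave open how an amine on this ring would read.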